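Moving the pyrazole attachment on the shared core

The source may report more compounds than this note shows. Statements on the series, on what has been measured and on what is new or still open speak of the compounds shown alone.

In an ADME assay on microsomes from liver (Mus musculus, strain CD-1) for metabolic stability, read by LC-MS, using NADPH, tested at 1 uM (on this read-out lower numbers stand for a shorter-lived compound and higher numbers for a longer-lived compound), compound 1 (`O=C(Nc1ccc(Cl)cc1)C1CCCN(C(=O)c2cccc(-c3ccco3)c2)C1`) gives 0.0267 h as its half-life. Compound 2 (`O=C(Nc1ccc(Cl)cc1)C1CCCN(C(=O)c2cncc(-c3ccco3)c2)C1`) gives < 0.05 h as a limit and not as a number. Compound 3 (`O=C(Nc1ccc(Cl)cc1)C1CCCN(C(=O)c2cccc(-n3cccn3)c2)C1`) gives 0.0283 h and stands level with compound 1 within the scatter, so it holds no real lead among the numbers available.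

The next structure is compound 4 (`O=C(Nc1ccc(Cl)cc1)C1CCCN(C(=O)c2cccc(-c3cn[nH]c3)c2)C1`), which keeps the same atoms joined differently. The change is 1H-pyrazol-4-yl in place of 1H-pyrazol-1-yl on an aromatic carbon and it sits on an aromatic carbon of a six-membered aromatic ring of carbon only, meta to a large group.

Within the data shown here, the one measured step that bears on this change is a 1.1-fold higher number from compound 1 to compound 3 (0.03 log units; within the scatter) on replacing furan-2-yl with 1H-pyrazol-1-yl at that place. That exchange of one five-membered aromatic ring for another left the half-life inside the scatter, so the working expectation is for no clear movement. Among the measured compounds shown here, no measured compound here carries 1H-pyrazol-4-yl, so the range is kept wide on both sides.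

The expected change is a 1.1-fold higher number from compound 3 to compound 4 (0.03 log units; within the scatter) and no direction beyond the scatter is anticipated. For compound 4 the estimated half-life is 0.03 h with an expected range from 0.012 h to 0.08 h in this assay for this compound.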

Compound 4, half-life: 0.0933 h
For compound 4 the middle estimate is 3.1-fold (0.49 log units) below the measured one; measured number outside the range, above it.
By their numbers in this assay, from the lowest: compounds 1 and 3 (each within the scatter of the next); then compound 4.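

At this position, on an aromatic carbon of a six-membered aromatic ring of carbon only, the attachment point of the pyrazole makes a measurable difference in this assay: with the same atoms joined differently, the record shows a 3.3-fold higher number from compound 3 to compound 4 (0.52 log units; beyond the scatter). The earlier exchange of furan-2-yl for 1H-pyrazol-1-yl stayed within the scatter, whereas 1H-pyrazol-4-yl also separates from furan-2-yl, with a 3.5-fold higher number from compound 1 to compound 4 (0.54 log units; beyond the scatter), so this position is not insensitive to the choice of five-membered aromatic ring. Nothing in the data shown accounts for the size or direction of these steps.

Going by these compounds, whether the step depends on the hydrogen-bond donor counted for 1H-pyrazol-4-yl remains open, and 1-methyl-1H-pyrazol-4-yl at the same place would test that directly. On these data alone, compound 2 gives < 0.05 h, a limit and not a number, so it remains open whether 1H-pyrazol-4-yl would bring a similar step on the core of that compound.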